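Methyl(tert-butyl)amino Replaces Aminoamino on the Amide

The compounds below may be only part of what the source reports. "The series", "measured", "known", "first", "only" and "open" are said of these compounds alone.

Compound 1 `CSc1nc(-c2cccc(F)c2)c2c(N)c(C(=O)NC(C)(C)C)sc2n1`: 1200 nM
Compound 2 `COc1cccc(-c2nc(SC)nc3sc(C(=O)NN)c(N)c23)c1`: "not determined" (no result reported)
Compound 3 `COc1cccc(-c2nc(SC)nc3sc(C(=O)N(C)C)c(N)c23)c1`: "not determined" (no result reported)

In a functional assay on HEK293 cells for agonist activity at lutropin-choriogonadotropic hormone receptor (Homo sapiens), read by cAMP accumulation (a higher number here means that more compound is needed for the effect, a lower number that less compound is needed), compound 1 gives 1200 nM. Compound 2 stands without a single number in this assay, and the same holds for compound 3, so no measured value anchors this pair. Compound 4 `COc1cccc(-c2nc(SC)nc3sc(C(=O)N(C)C(C)(C)C)c(N)c23)c1` has not yet been measured. It differs from compound 2 in one place: methyl(tert-butyl)amino in place of aminoamino on a carbonyl carbon. For the measured compounds named here, no measured pair of this kind exists, so the size of the step cannot be read from the data; in this assay a shift in either direction, or none beyond the scatter, remains possible. Compound 4 is expected to give about 1500 nM, with an estimated range from 300 nM to 8000 nM.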

Compound 4, half-maximal effective concentration: 800 nM
Estimate against measurement, compound 4: 1.9-fold (0.27 log units) above, and the stated range covers the measured number.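

For the compounds shown here, compound 2 has no single number in this assay, so no step to compound 4 can be read. On these data alone, what replacing aminoamino with methyl(tert-butyl)amino does to the effect stays open, and no evidence here bears on this result.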